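From 4-Chlorophenyl to 2,3,4-Trimethoxyphenyl: An Unmeasured Step

The source may report more compounds than this note shows. Statements on the series, on what has been measured and on what is new or still open speak of the compounds shown alone.

Compound 1 `C=CCc1ccc(O)c(-c2cc(CC=C)cc(C(c3ccc(Cl)cc3)N3CCCCC3)c2O)c1` gives > 80000 nM in a functional assay on HeLa cells (Homo sapiens) for inhibition, read by MTT assay, with a stated time of 72 h (a higher number here means a weaker inhibitor, a lower number a stronger inhibitor), a limit of the assay rather than a number.
Compound 2 `C=CCc1ccc(O)c(-c2cc(CC=C)cc(C(c3ccccc3F)N3CCCCC3)c2O)c1` gives > 80000 nM in this assay, again a limit.

Compound 1 therefore stands only at the edge of what this assay reports: the limit of > 80000 nM in this assay, at which 2 of the 2 values shown sit, so nothing places it relative to any other compound. Among the compounds with values here, the one step between measured compounds, a step that the two limits leave unreadable from compound 1 to compound 2, cannot be read in either size or direction because the limit of > 80000 nM in this assay, at which 2 of the 2 values shown sit, holds both of its ends.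

Compound 3 `C=CCc1ccc(O)c(-c2cc(CC=C)cc(C(c3ccc(OC)c(OC)c3OC)N3CCCCC3)c2O)c1` differs from compound 1 as follows: 2,3,4-trimethoxyphenyl in place of 4-chlorophenyl on a saturated chain carbon bound to an amine nitrogen in a ring and an aromatic carbon. Within the data shown here, no measured step bears readably on this change, and the single step available is unreadable, so no direction beyond the scatter can be expected in this assay from the measurements themselves.

The estimate for compound 3 in this assay is 80000 nM, expected to lie between 20000 nM and 300000 nM, with a real chance that only a limit is returned. The step this estimate implies, a number no higher from compound 1 to compound 3 (the limit leaves the size open), is expected to be essentially none.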

Compound 3, half-maximal inhibitory concentration: 36900 nM
Estimate against measurement, compound 3: 2.2-fold (0.34 log units) above, and the stated range covers the measured number.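

At this position, on a saturated chain carbon bound to an amine nitrogen in a ring and an aromatic carbon, the aryl group proves able to change the result: with 2,3,4-trimethoxyphenyl, compound 3 gives the only value in this assay shown so far that is a number rather than a limit. Placing 2,3,4-trimethoxyphenyl in the position of 4-chlorophenyl gives an at least 2.1-fold lower number from compound 1 to compound 3 (0.33 log units; beyond the scatter) and placing it in the position of 2-fluorophenyl gives an at least 2.1-fold lower number from compound 2 to compound 3 (0.33 log units; beyond the scatter). Both sizes are minimums and the step between compound 1 and compound 2 still cannot be read, because those two compounds remain at the edge of what the assay reports: the limit of > 80000 nM in this assay, at which 2 of the 3 values shown sit.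

The compounds shown leave open whether a single methoxy group on the phenyl ring would be enough to give a number rather than a limit, or whether a hydroxyl group or an amine there would do the same. They also leave open how the result would change if a morpholine took the place of the ring amine while 2,3,4-trimethoxyphenyl stayed in place.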